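Inverting Every Stereocentre of Compound 1

The source may hold more compounds than are shown below. What is called first, only, known or untested is meant among the compounds shown, and "the series" means these compounds.

Of the compounds shown here, three with a shared core have been measured in a functional assay on HL-60 cells (Homo sapiens) for antiproliferative activity, read by MTT assay, with a stated time of 72 h; a higher number here means a weaker inhibitor, a lower number a stronger inhibitor. Compound 1 `O=C1C[C@@H]2O[C@@H](Cc3ccccc3)[C@@H](O)[C@@H]2O1` gives 170 nM, the lowest number of the three and so the most potent of this small set. Compound 2 `O=C1C[C@H]2O[C@H](Cc3ccccc3)[C@H](OCc3ccccc3)[C@H]2O1` is the nearest, at 560 nM, and this gap lies beyond the scatter. Compound 3 `O=C1C[C@@H]2O[C@H]3[C@H](c4ccccc4)c4ccccc4CO[C@H]3[C@@H]2O1` is the furthest, at 11700 nM, well beyond the scatter.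

The next compound, compound 4 `O=C1C[C@H]2O[C@H](Cc3ccccc3)[C@H](O)[C@H]2O1`, has the same atoms and bonds as compound 1. The change is the two compounds have the same atoms and bonds and differ only in configuration as drawn: 4 of 4 stereo elements differ (all stereocentres are inverted: mirror images); a stereocentre at a saturated ring carbon is drawn S in compound 1 and R in compound 4; a stereocentre at a saturated ring carbon is drawn S in compound 1 and R in compound 4; a stereocentre at a saturated ring carbon is drawn R in compound 1 and S in compound 4; a stereocentre at a saturated ring carbon is drawn S in compound 1 and R in compound 4. Nothing leaves and nothing enters, so the two compounds are mirror images.

Among the measured compounds shown here, no measured pair in this assay differs in one place, so the data give no direct size for this kind of change. Compound 1 already holds the lowest number at 170 nM, and the three measured values show that this series can span a wide range. A modest move towards a weaker number is therefore expected, though a result within the scatter would not be surprising. The expected step is a 1.8-fold higher number from compound 1 to compound 4 (0.25 log units; within the scatter). For compound 4 the estimated value is 300 nM, with an expected range from 60 nM to 1500 nM.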

Compound 4, half-maximal inhibitory concentration: 43800 nM
Estimate against measurement, compound 4: 150-fold (2.16 log units) below; the measured number lies above the stated range.
By their numbers in this assay, from the lowest: compound 1; then compound 2; then compound 3; then compound 4.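

In this assay, among the compounds shown here, the mirror-image change is far from neutral: it brings a 260-fold higher number from compound 1 to compound 4 (2.41 log units; beyond the scatter), and the earlier compounds, with no step between them, could not show that configuration alone moves the number this far. Nothing enters or leaves in this step, so the whole gap belongs to the inversion of the stereocentres, because the structures offer no other difference: the fact that compounds 1 and 4 differ only in the configuration as drawn. The second step, a 78-fold higher number from compound 2 to compound 4 (1.89 log units; beyond the scatter), comes with hydrogen in place of benzyl on an oxygen on a saturated carbon, which shows that within this configuration the group on that oxygen also matters a great deal.

The compounds shown leave open which of the four stereocentres carries the step, since all of them change together, and whether inverting only one or two would already cost as much. They also leave open how the configuration of compound 1 responds to a benzyl group on that oxygen, and whether a methyl ether, an acetate ester or an amine in that place would follow the same direction in either configuration.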